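Smaller acyl group on the shared core: expectation for compound 4

The source may report more compounds than this note shows. Statements on the series, on what has been measured and on what is new or still open speak of the compounds shown alone.

Compound 1 `Cc1cccc(Cn2c(CN3CCN(C(=O)c4ccc([N+](=O)[O-])cc4)CC3)nc3ccccc32)c1` has the lowest number of the three measured. In an assay on isolated protein for inhibition of aldehyde dehydrogenase 1A1 (Homo sapiens), read by spectrophotometry, tested at 10 uM (a higher number here means more inhibition at the concentration tested (going by the name of the read-out), a lower number less inhibition), compound 1 gives 24.3%, beyond the scatter below both compound 2 `O=C(C1CC1)N1CCN(Cc2nc3ccccc3n2Cc2ccccc2F)CC1`, which gives 40.7%, and compound 3 `CC(C)CCn1c(CN2CCN(C(=O)c3ccco3)CC2)nc2ccccc21`, which gives 42.1%. Both companions differ from compound 1 in the group on the carbonyl carbon. Compound 4 `CCC(=O)N1CCN(Cc2nc3ccccc3n2Cc2cccc(C)c2)CC1` is not yet measured; it differs from compound 1 as follows: ethyl in place of 4-nitrophenyl on a carbonyl carbon. For the measured compounds named here, no step between measured compounds is known, so the size of this change can only be expected. Because compound 2 gives 40.7% and compound 3 gives 42.1% with other groups on that carbonyl carbon, compound 4 is expected to rise toward that range, the estimated step being a number 13.7 percentage points higher from compound 1 to compound 4 (beyond the scatter). Compound 4 is estimated at 38%, within 22% to 54%.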

Compound 4, a percentage reported as inhibition, at one concentration (the size of the read-out at that concentration, not a potency): 85.1%
Estimate against measurement, compound 4: 47.1 percentage points below; measured number above the stated range.
By their numbers in this assay, from the lowest: compound 1; then compounds 2 and 3 (each within the scatter of the next); then compound 4.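

In this assay, for the compounds shown here, ethyl in place of 4-nitrophenyl on a carbonyl carbon gives a number 60.8 percentage points higher from compound 1 to compound 4 (beyond the scatter) as the only step read directly at this position. With the rest of compound 1 unchanged, this single change from (4-nitrophenyl)carbonyl to propanoyl shows that the group at this position can strongly alter the read-out on the shared core. Nothing measured here explains the step.

Phenyl without the nitro group, methyl and a longer chain such as butyl remain open at this position. These would show whether the ring, the nitro group or the chain length governs the size of the step.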